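This account rests on a few compounds, and the source may have more. Where it says the series, first, only, none or still open, it means among the compounds named here.

Measured so far:
compound 1, `O=C(O)Cc1sc(Cc2ccccc2)nc1-c1ccc(Cl)cc1`: 50%
compound 2, `O=C(O)Cc1sc(C(c2ccc(F)cc2)c2ccc(F)cc2)nc1-c1ccnc(Cl)c1`: 80%

In an in vitro functional assay on HEK285-7 cells for antagonist activity at prostaglandin D2 receptor 2 (Homo sapiens), read by BRET and beta-arrestin recruitment (on this read-out lower numbers stand for smaller maximal responses and higher numbers for larger maximal responses), compound 2 gives 80%, the higher of the two numbers obtained so far. Compound 1 gives 50% in this assay, and the gap between the two is beyond the scatter. The two compounds differ in more than one place, so no single change has yet been tied to a shift on this read-out, and nothing in the series shows how one substituent exchange moves the maximal response.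

Compound 3, `Cc1cc(-c2nc(C(c3ccc(F)cc3)c3ccc(F)cc3)sc2CC(=O)O)ccn1`, has not yet been measured. Against compound 2 it carries one change: methyl in place of chloro on an aromatic carbon. The exchange is small in size, one heavy atom leaving and one entering, and reads as 2-chloropyridin-4-yl to 2-methylpyridin-4-yl.

Within the data shown here, with no measured step of this kind to lean on, the expected step in this assay is a number 4 percentage points lower from compound 2 to compound 3 (within the scatter), that is, none beyond the scatter, with the direction left open. Compound 3 is estimated at 76%, with a range from 56% to 96%.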

Compound 3, largest response reached (reported as efficacy), in percent of the reference or control that the assay uses: 80%
Compound 3: middle estimate off by 4 percentage points, on the low side, and the stated range covers the measured number.
By their numbers in this assay, from the lowest: compound 1; then compounds 2 and 3 (each within the scatter of the next).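

Among these compounds, the only single-place step so far reads no change at the digits printed from compound 2 to compound 3 (within the scatter) in this assay when methyl takes the place of chloro on the aromatic carbon next to the ring nitrogen, with the rest of the structure unchanged. On this background, then, the exchange of 2-chloropyridin-4-yl for 2-methylpyridin-4-yl leaves the maximal response indistinguishable, so this read-out does not separate the two substituents at this position, though that rests on a single pair. Nothing on hand speaks to why the two substituents read alike here.

As far as these compounds go, how an amine, a methoxy group or a longer chain such as propyl on the same carbon would move the maximal response stays open, so the pair shows only that these two substituents read alike, not how far the position tolerates change. Also open, from the compounds shown here alone, is whether the same exchange would read alike on the background of compound 1, and the gap between compound 1 and compound 2 remains tied to no single change, as those two compounds differ in more than one place.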